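Estimating compound 3 from two limits

A few compounds are considered here, and "the series" means these few. Any claim that something is new, unique, unknown or untested is made for them only; others in the source may bear on it.

Compound 1 `COc1cc(/C=N/NC(=O)c2cn(C3CC3)c3cc(N4CCNCC4)c(F)cc3c2=O)cc(OC)c1OC` gives the limit <= 25000 nM
Compound 2 `COc1ccc(/C=N/NC(=O)c2cn(C3CC3)c3cc(N4CCNCC4)c(F)cc3c2=O)cc1O` gives the limit <= 25000 nM

Both results come from a functional assay on HL-60 cells (Homo sapiens) for antiproliferative activity, read by MTT assay (a lower number here means a stronger inhibitor, a higher number a weaker inhibitor), and neither is an exact number. Compound 2 therefore has no precise place on the scale, and the one other result beside it is also only a limit. The two results are summed up in the limit of <= 25000 nM in this assay, at which 2 of the 2 values shown sit, and nothing finer can be read from them. For the measured compounds named here, the only measured step is a step that the two limits leave unreadable from compound 1 to compound 2 and it offers no size to carry forward.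

Compound 3 `O=C(N/N=C/c1ccccc1[N+](=O)[O-])c1cn(C2CC2)c2cc(N3CCNCC3)c(F)cc2c1=O` keeps the shared core but carries 2-nitrophenyl in place of 3-hydroxy-4-methoxyphenyl on a carbon with a double bond to nitrogen. Going by the values given here, the difference 2-nitrophenyl in place of 3-hydroxy-4-methoxyphenyl on a carbon with a double bond to nitrogen is the only change between the two structures.

With no readable step to lean on, neither a gain nor a loss can be expected, so the working expectation in this assay is no change beyond the scatter. The estimated step is a step that the limit leaves unreadable from compound 2 to compound 3 and it remains only an expectation. The expected value for compound 3 is 12000 nM with an estimated range from 3000 nM to 30000 nM and the result may well arrive as another limit.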

Compound 3, half-maximal inhibitory concentration: <= 25000 nM
Compound 3 was reported as a limit; the forecaster's own chance of this, stated with the estimate: 45%; the middle value lies beyond the limit too.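

In this assay compound 3 is reported only as a limit, like compound 1 and compound 2, and the steps among the three cannot be read: the limit of <= 25000 nM in this assay, at which 3 of the 3 values shown sit.

The compounds shown leave open how far apart the 2-nitrophenyl, 3-hydroxy-4-methoxyphenyl and 3,4,5-trimethoxyphenyl compounds truly lie, and whether exchanging these groups changes the activity at all.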